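Methoxy for dimethylamino on the aryl of compound 1

The source may report more compounds than this note shows. Statements on the series, on what has been measured and on what is new or still open speak of the compounds shown alone.

Compound 1 `Cc1ccc2nc(-c3ccc(N(C)C)cc3)c(NC3CCCCC3)n2c1` is tested in an assay on cells for inhibition of Polyunsaturated fatty acid 5-lipoxygenase (Homo sapiens), read by HPLC, with stated times of 15 min and 10 min; on this read-out higher numbers stand for weaker inhibition and lower numbers for stronger inhibition; in this assay compound 1 gives 600 nM. The other measured member of the series, compound 2 `Cc1ccc(-c2nc3cc(C)ccn3c2NC2CCCC2)cc1`, gives 900 nM in this assay. The two numbers lie within the usual scatter of each other, so no order between compound 1 and compound 2 can be read from them. Going by the values given here, compound 2 also differs from compound 1 in more than one place, so no single step between measured compounds is available.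

Compound 3 `COc1ccc(-c2nc3ccc(C)cn3c2NC2CCCCC2)cc1` is not yet measured. It differs from compound 1 by methoxy in place of dimethylamino on an aromatic carbon; in words, methoxy in place of dimethylamino on an aromatic carbon. Among the compounds with values here, no measured pair shows this change, so the size of its step in this assay cannot be taken from the data. The expectation is a step within the scatter or only a little beyond it, if anything toward a higher number. For compound 3 the estimated step is a 1.5-fold higher number from compound 1 to compound 3 (0.18 log units; within the scatter). Compound 3 is thus expected to give 900 nM in this assay, with a range of 300 nM to 2700 nM.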

Compound 3, half-maximal inhibitory concentration: 1300 nM
The estimate for compound 3 lay 1.4-fold (0.16 log units) below the measured number; low and high end bracket the measured number.
By their numbers in this assay, from the lowest: compounds 1, 2 and 3 (each within the scatter of the next, the first and the last beyond it).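

In this assay, going by these compounds alone, the position on the aromatic ring para to a large group now has its only single-change reading: methoxy in place of dimethylamino gives a 2.2-fold higher number from compound 1 to compound 3 (0.34 log units; beyond the scatter) and this modest step lies beyond the scatter. On the core of compound 1, dimethylamino therefore gives the lower number of the two groups, so methoxy is not a neutral replacement at this position, although the difference is small. The computed comparison counts no hydrogen-bond donors and one hydrogen-bond acceptor for each group, and no available measurement explains the difference in their numbers.

Going by these compounds, it remains open whether an amino group, a methylamino group, a hydroxyl group or a chlorine atom at this position would stay with dimethylamino or with methoxy in this assay. On these data alone, it is also open whether the same change would give a step of similar size on the core of compound 2, which carries a cyclopentyl group on its amine rather than the cyclohexyl group of compound 1.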